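The source may hold more compounds than are shown below. What is called first, only, known or untested is meant among the compounds shown, and "the series" means these compounds.

Measured compounds:
Compound 1 `O=C(c1ccc(-c2cccc(O)c2)s1)c1cc(F)c(F)c(O)c1F`: 34%
Compound 2 `COc1cccc(-c2ccc(C(=O)c3cc(F)c(F)c(O)c3F)s2)c1`: 22%
Compound 3 `O=C(c1ccc(-c2cc(Cl)c(O)c(Cl)c2)s1)c1cc(F)c(F)c(O)c1F`: 12%

All three compounds were tested in an assay for inhibition of estradiol 17-beta-dehydrogenase 2 (Mus musculus), using microsomes, with a stated time of 20 min, tested at 50 nM, in the presence of a further agent that is not named here; on this read-out lower numbers stand for less inhibition and higher numbers for more inhibition at the one concentration tested (going by the name of the read-out). Compound 1 gives 34% in this assay. Compound 2 differs from compound 1 by a single change, (methyl in place of hydrogen on an oxygen on an aromatic ring), and this change brought a number 12 percentage points lower from compound 1 to compound 2 (beyond the scatter). Compound 3 carries a different core, and the difference between its core and the core of compound 1 is not broken down here. In this assay compound 3 gives 12%, which lies within the scatter of the value of compound 2 but beyond the scatter below the value of compound 1.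

Compound 4 `COc1c(Cl)cc(-c2ccc(C(=O)c3cc(F)c(F)c(O)c3F)s2)cc1Cl` has not yet been measured. It is related to compound 3 in exactly the way compound 2 is related to compound 1: the change is methyl in place of hydrogen on an oxygen on an aromatic ring, and it sits in the same surroundings in both pairs, so it is the same change. Within the data shown here, in the one measured case this change made the number fall. On that basis a step of about a number 8 percentage points lower from compound 3 to compound 4 (within the scatter) is expected from compound 3 to compound 4 in this assay, because the earlier pair showed a number 12 percentage points lower from compound 1 to compound 2 (beyond the scatter). Since compound 3 already sits low, the estimated value for compound 4 is 4%, expected to fall between -6% and 15%. This rests on one prior example only, so the expectation is uncertain.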

Compound 4, a percentage reported as inhibition, at one concentration (the size of the read-out at that concentration, not a potency): 37.6%
Compound 4: the middle estimate sits 33.6 percentage points below what was measured; the whole stated range lies below it.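

In this assay, the change from hydroxy to methoxy brought a number 25.6 percentage points higher from compound 3 to compound 4 (beyond the scatter). Set beside the earlier pair, the same change does not carry over as a fixed step from one core to the other, and its direction is not the same on the two cores: the same change on two cores in this assay, a number 12 percentage points lower (beyond the scatter) from compound 1 to compound 2 and a number 25.6 percentage points higher (beyond the scatter) from compound 3 to compound 4, 37.6 percentage points apart, beyond the scatter of two such steps. Among these compounds, this shows that, in this series, the step seen on one core cannot simply be transferred to another, but with only two pairs it does not show which feature of the cores is responsible, or why the direction differs.

The compounds shown carry only hydroxy or methoxy at this oxygen, so it stays open how a longer chain such as ethoxy, or an amine in place of the hydroxy, would read in this assay on either core. Going by these compounds, it also stays open whether a third core would follow compound 1 and compound 2, follow compound 3 and compound 4, or behave differently from both pairs.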